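A few compounds are considered here, and "the series" means these few. Any claim that something is new, unique, unknown or untested is made for them only; others in the source may bear on it.

Measured compounds:
compound 1 `CCOc1nc(CC)n2c1C(CCc1ccc(C(F)(F)F)cc1)N([C@@H](C(=O)NC)c1ccccc1)CC2`: 2750 nM
compound 2 `CCc1nc(C)c2n1CCN([C@@H](C(=O)NC)c1ccccc1)C2CCc1ccc(C(F)(F)F)cc1`: 24 nM
compound 3 `CCc1ncc2n1CCN([C@@H](C(=O)NC)c1ccccc1)C2CCc1ccc(C(F)(F)F)cc1`: 194 nM

In a functional assay on CHO cells for antagonist activity at Orexin receptor type 2 (Homo sapiens), read by FLIPR and calcium flux (on this read-out higher numbers stand for weaker inhibition and lower numbers for stronger inhibition), compound 3 stands second highest of the three numbers, with compound 2 nearest and compound 1 furthest. Compound 4 `CCc1nc(C(=O)N(C)C)c2n1CCN([C@@H](C(=O)NC)c1ccccc1)C2CCc1ccc(C(F)(F)F)cc1` differs from compound 3 by dimethylcarbamoyl in place of hydrogen on an aromatic carbon. The step that bears most on it is an 8.1-fold higher number from compound 2 to compound 3 (0.91 log units; beyond the scatter), which shows that a small group at this carbon gave a lower number than hydrogen; yet a 110-fold lower number from compound 1 to compound 2 (2.06 log units; beyond the scatter) and a 14-fold lower number from compound 1 to compound 3 (1.15 log units; beyond the scatter) show that a larger ethoxy group gave a much higher number. A dimethylcarbamoyl group is also sizeable, so the direction is uncertain; a change within the scatter or a modest shift is expected, a 1.3-fold lower number from compound 3 to compound 4 (0.11 log units; within the scatter). Compound 4 is estimated at 150 nM, within 25 nM to 900 nM.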

Compound 4, half-maximal inhibitory concentration: 111 nM
For compound 4 the middle estimate is 1.4-fold (0.13 log units) above the measured one; low and high end bracket the measured number.
By their numbers in this assay, from the lowest: compound 2; then compounds 4 and 3 (each within the scatter of the next); then compound 1.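

In this assay, dimethylcarbamoyl on this aromatic carbon gives a number within the scatter of hydrogen (a 1.7-fold lower number from compound 3 to compound 4 (0.24 log units; within the scatter)). Set against the other two groups, it gives a higher number than methyl (a 4.6-fold higher number from compound 2 to compound 4 (0.67 log units; beyond the scatter)) but a far lower one than ethoxy (a 25-fold lower number from compound 1 to compound 4 (1.39 log units; beyond the scatter)), so a sizeable group here need not bring the high number seen with ethoxy. No measurement shown explains these differences. Still open, on these data alone, is how a nitrile, an amine or a carboxylic acid on this carbon would compare with methyl.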